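The compounds below may be only part of what the source reports. "The series", "measured", "known", "first", "only" and "open" are said of these compounds alone.

The measured compounds:
Compound 1, `CCOCn1c(N)c(C#N)c2c(N)ncnc21`: 138000 nM
Compound 2, `CCOCn1cc(C(=N)S)c2c(N)ncnc21`: 60000 nM
Compound 3, `CCOCn1cc(C#N)c2c(N)ncnc21`: > 100000 nM, a limit of the assay rather than a number

All three share one core and were compared in a functional assay on KB cells (Homo sapiens) for inhibition; on this read-out higher numbers stand for weaker inhibition and lower numbers for stronger inhibition. Compound 2 stands lowest of the two numbers. The step of an at least 1.6-fold higher number from compound 2 to compound 3 (0.22 log units; that floor lies within the scatter), the change (a group of 3 heavy atoms (1 carbon, 1 nitrogen, 1 sulfur; no ring) in place of a group of 2 heavy atoms (1 carbon, 1 nitrogen; no ring), on an aromatic carbon), is only a floor because of the limit of > 100000 nM in this assay, at which 1 of the 3 values shown sits. The amino change amino in place of hydrogen on an aromatic carbon gives the step that the limit leaves unreadable from compound 3 to compound 1, which is unreadable because of the limit of > 100000 nM in this assay, at which 1 of the 3 values shown sits.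

Compound 4, `CCOCn1c(N)c(C(=N)S)c2c(N)ncnc21`, carries the same kind of change, (amino in place of hydrogen on an aromatic carbon); the place differs in that the ring atom next to it bears a group of 3 heavy atoms instead of a cyano group (2 heavy atoms). Since the amino change left compound 1 at 138000 nM with no visible gain, compound 4 is expected to show a 1.5-fold higher number from compound 2 to compound 4 (0.18 log units; within the scatter). Compound 4 is estimated at 90000 nM, expected between 40000 nM and 200000 nM.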

Compound 4, half-maximal inhibitory concentration: > 320000 nM
Compound 4 gave a limit, no number; the forecaster's own chance of this, stated with the estimate: 30%; at least 3.5-fold (0.55 log units) between middle value and limit.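

Compound 4 gives > 320000 nM in this assay, which is a limit and not a number. Even so, amino in place of hydrogen gives an at least 5.3-fold higher number from compound 2 to compound 4 (0.72 log units; beyond the scatter), while the group of 3 heavy atoms in place of the nitrile gives an at least 2.3-fold higher number from compound 1 to compound 4 (0.36 log units; beyond the scatter). These steps are floors and the step from compound 3 to compound 1 cannot be read, so the true sizes stay unknown, but the exchange between nitrile and the group of 3 heavy atoms does not carry over unchanged from one core to the other: the same change on two cores in this assay, an at least 1.6-fold higher number (0.22 log units; that floor lies within the scatter) from compound 2 to compound 3 and an at least 2.3-fold lower number (0.36 log units; beyond the scatter) from compound 4 to compound 1, at least 3.8-fold (0.58 log units) apart, beyond the scatter of two such steps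

The compounds shown leave open how a methylamino group or a hydroxyl group would compare with amino on the same aromatic carbon. They also leave open how a carboxylic acid would compare with the nitrile.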